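This account rests on a few compounds, and the source may have more. Where it says the series, first, only, none or still open, it means among the compounds named here.

Of the compounds shown here, two have so far been measured in a functional assay on THP-1 cells (Homo sapiens) for inhibition; on this read-out lower numbers stand for stronger inhibition and higher numbers for weaker inhibition. Compound 1 `C[C@H](NC(=O)C(=O)Nc1ccccc1Br)C(=O)N[C@@H](CC(=O)O)C(=O)COc1c(F)c(F)cc(F)c1F` gives 50 nM in this assay. Compound 2 `C[C@H](NC(=O)C(=O)Nc1ccccc1-c1ccccc1)C(=O)N[C@@H](CC(=O)O)C(=O)COC(=O)c1c(F)c(F)cc(F)c1F` gives 500 nM, the higher of the two numbers, with compound 1 standing at a lower number by a gap beyond the scatter. Compound 3 `C[C@H](NC(=O)C(=O)Nc1ccccc1-c1ccccc1)C(=O)N[C@@H](CC(=O)O)C(=O)COC(=O)c1c(Cl)cccc1Cl` differs from compound 2 in one place: 2,6-dichlorophenyl in place of 2,3,5,6-tetrafluorophenyl on a carbonyl carbon. For the measured compounds named here, no measured pair shows this change, so nothing here tells its size. The expected step of no change at the digits printed from compound 2 to compound 3 (within the scatter) is small, in either direction or none beyond the scatter. Compound 3 is therefore estimated at about 500 nM, in the range 150 nM to 1500 nM.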

Compound 3, half-maximal inhibitory concentration: 4360 nM
The estimate for compound 3 lay 8.7-fold (0.94 log units) below the measured number, and the stated range ends below it.
By their numbers in this assay, from the lowest: compound 1; then compound 2; then compound 3.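

In this assay, the group on this carbonyl carbon clearly matters: 2,6-dichlorophenyl in place of 2,3,5,6-tetrafluorophenyl gives an 8.7-fold higher number from compound 2 to compound 3 (0.94 log units; beyond the scatter) and so weakens inhibition beyond the scatter. The two groups therefore cannot be treated as interchangeable on this scaffold. No measurement shown here explains the step.
On these data alone, it remains open whether an unsubstituted phenyl or a 2,6-difluorophenyl group at this place would stay near compound 2 or fall near compound 3. As far as these compounds go, whether the same swap has a similar effect with other groups elsewhere on the shared core also remains open.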